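This account rests on a few compounds, and the source may have more. Where it says the series, first, only, none or still open, it means among the compounds named here.

Working notes on the series, all read in a functional assay on A20 cells (Mus musculus) for inhibition, with stated times of 1 h, 16 h and 24 h; a lower number here means a stronger inhibitor, a higher number a weaker inhibitor. Compound 1 (`N#CCNC(=O)[C@@H]1CC(F)(F)C[C@H]1C(=O)N1CCOCC1`) gives 925 nM, compound 2 (`N#CCNC(=O)[C@@H]1C[C@@H](S(=O)(=O)c2ccccc2C(F)(F)F)C[C@H]1C(=O)N1CCOCC1`) gives 2 nM and compound 3 (`C[C@@H]1CN(C(=O)[C@@H]2C[C@H](S(=O)(=O)c3ccccc3)C[C@H]2C(=O)NC2(C#N)CC2)C[C@H](C)O1`) gives 1 nM. The last two numbers lie within the scatter of each other, so compound 3 stands level with compound 2 at the low end of the three. Compound 1 stands well beyond the scatter on the weaker side of both.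

The next entry is compound 4 (`N#CC1(NC(=O)[C@@H]2C[C@@H](S(=O)(=O)c3ccccc3)C[C@H]2C(=O)N2CCS(=O)(=O)CC2)CC1`). It carries 1,1-dioxothiomorpholin-4-yl in place of the 2,6-dimethylmorpholin-4-yl of compound 3 on a carbonyl carbon: 1,1-dioxothiomorpholin-4-yl in place of 2,6-dimethylmorpholin-4-yl on a carbonyl carbon. Among the compounds with values here, no measured pair differs at this place alone, so the data give no direct size for such a step. Compound 2 at 2 nM and compound 3 at 1 nM differ at this carbonyl as well as elsewhere, and they still stay within the scatter, which points to a small effect at most. In this assay a modest move towards weaker inhibition is expected, about the size of the scatter or slightly more. The expected change is a 3.0-fold higher number from compound 3 to compound 4 (0.48 log units; beyond the scatter). Compound 4 is estimated at 3 nM, with an expected range of 1 nM to 12 nM.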

Compound 4, half-maximal inhibitory concentration: 816 nM
Compound 4: middle estimate off by 270-fold (2.43 log units), on the low side; the measured number lies above the stated range.
By their numbers in this assay, from the lowest: compounds 3 and 2 (each within the scatter of the next); then compounds 4 and 1 (each within the scatter of the next).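

In this assay, within the data shown here, the group on this carbonyl carbon turns out not to be a tolerant place: the step is an 820-fold higher number from compound 3 to compound 4 (2.91 log units; beyond the scatter), with 1,1-dioxothiomorpholin-4-yl in place of 2,6-dimethylmorpholin-4-yl as the only change. Among these compounds, this is the first step that isolates a single place, and it shows that this exchange alone is enough to turn a low-nanomolar inhibitor into a much weaker one, even with the rest of the structure kept. The data at hand offer no measurement that accounts for the size of this step.

The single exchange alters several things at once, so the compounds shown do not separate the loss of the methyl groups from the entry of the ring sulfur and its two oxygens; a plain morpholin-4-yl or an unoxidised thiomorpholin-4-yl on this carbonyl would divide the step. From the compounds shown here alone, it also stays open how a ring with a basic amine, such as piperazin-1-yl, would read here, and whether the same exchange costs as much alongside the trifluoromethyl-substituted aryl sulfone of compound 2.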